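The compounds below may be only part of what the source reports. "The series", "measured", "known", "first", "only" and "open" are said of these compounds alone.

Of the compounds shown here, two have a measured number so far. Compound 1 `COc1ccc(C#N)cc1Sc1ccc2nnc(-c3cnn(C)c3)n2n1` gives 64 nM in an assay on isolated protein for inhibition of Leucine-rich repeat serine/threonine-protein kinase 2 (Homo sapiens), in the presence of a further agent that is not named here (a higher number here means a weaker inhibitor, a lower number a stronger inhibitor), and compound 2 `COc1ccc(Cl)cc1Sc1ccc2nnc(-c3cnn(C)c3)n2n1` gives 78 nM. For the measured compounds named here, the only change between them is a 1.2-fold higher number from compound 1 to compound 2 (0.09 log units; within the scatter), so the two numbers cannot be told apart. Among the two measured numbers, compound 2 carries the higher one, with compound 1 as its nearest neighbour at a distance that lies within the scatter.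

Compound 3 `Cn1cc(-c2nnc3ccc(Sc4cc(Cl)ccc4Cl)nn23)cn1` is the next step from compound 2. The change is chloro in place of methoxy on an aromatic carbon: the methoxy group that sits ortho to a large group and para to a chloro group is replaced by a chloro group. Going by the values given here, no measured step touches this position, and the single step known from compound 1 to compound 2 concerns a different group elsewhere on the same ring, so nothing directly informs the size or direction of the step. The expectation is therefore a step of a 1.2-fold higher number from compound 2 to compound 3 (0.06 log units; within the scatter), no larger than the scatter. Compound 3 is estimated to give 90 nM, within a range from 35 nM to 250 nM.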

Compound 3, half-maximal inhibitory concentration: 373 nM
Estimate against measurement, compound 3: 4.1-fold (0.62 log units) below, outside the stated range (above it).
By their numbers in this assay, from the lowest: compounds 1 and 2 (each within the scatter of the next); then compound 3.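

For the compounds shown here, the methoxy group that sits ortho to a large group is the first place where a single change moves the number beyond the scatter. In this assay, chloro in place of methoxy gives a 4.8-fold higher number from compound 2 to compound 3 (0.68 log units; beyond the scatter), so compound 3 is a weaker inhibitor than compound 2, whereas chloro in place of cyano elsewhere on the same ring gave only a 1.2-fold higher number from compound 1 to compound 2 (0.09 log units; within the scatter), which is within the scatter. The methoxy-to-chloro swap removes one hydrogen-bond acceptor and one heavy atom, but these are only counted differences, and no measurement here explains the rise in the number.

As far as these compounds go, it remains open whether an ethoxy group, a hydroxyl or an amine at this place would stay close to compound 2 at 78 nM or would behave like the chloro group of compound 3. Also open, from the compounds shown here alone, is whether the same swap would give a step of similar size with the cyano group of compound 1 in place of the chloro group that sits para to this position.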